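The compounds below may be only part of what the source reports. "The series", "measured", "known", "first", "only" and "open" are said of these compounds alone.

Among the measured compounds shown here, in a functional assay on K562 cells (Homo sapiens) for cytotoxicity, read by MTT assay, with a stated time of 24 h (on this read-out higher numbers stand for weaker inhibition and lower numbers for stronger inhibition), only two compounds have been measured so far. Compound 2 (`COc1cc(/C=C2\CN(C)C/C(=C\c3ccc(F)cc3)C2=O)cc(OC)c1OC`) gives 10300 nM, and compound 1 (`COc1cc(/C=C2\CN(C)C/C(=C\c3ccc(Cl)cc3)C2=O)cc(OC)c1`) gives 13300 nM. These two values lie within the usual scatter of each other, so the data do not separate the two compounds, and compound 2 stands level with compound 1 in the low-potency micromolar part of the scale.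

The next compound, compound 3 (`COc1cc(/C=C2\CN(C)C/C(=C\c3ccc(Cl)cc3)C2=O)cc(OC)c1OC`), departs from compound 2 in one place only: chloro in place of fluoro on an aromatic carbon. This is the change from 4-fluorophenyl to 4-chlorophenyl, with chloro in place of fluoro on an aromatic carbon. For the measured compounds named here, no measured pair here differs in one place alone, so no measured step guides the size of this one. The 4-chlorophenyl group is already present in compound 1, although that compound differs from compound 3 elsewhere, and compound 1 gives 13300 nM. The expected change, a 1.0-fold higher number from compound 2 to compound 3 (0.01 log units; within the scatter), is therefore estimated to stay within the scatter, with no clear direction. For compound 3 the expected value is 10500 nM, with an estimated range from 5000 nM to 21000 nM.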

Compound 3, half-maximal inhibitory concentration: > 20000 nM
Compound 3 gave a limit, no number (the forecaster's own chance of this, stated with the estimate: 3%); middle value at least 1.9-fold (0.27 log units) away from the limit.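

In this assay compound 3 gives > 20000 nM, which is a limit of the assay and not a number, so this result bounds its potency on one side only: the limit of > 20000 nM in this assay, at which 1 of the 3 values shown sits. Chloro in place of fluoro, on an aromatic carbon para to a large group, now provides the first step in this series that differs in one place, an at least 1.9-fold higher number from compound 2 to compound 3 (0.28 log units; that floor lies within the scatter), and the printed floor of that step lies within the scatter. Methoxy in place of hydrogen on an aromatic carbon provides a second such step, an at least 1.5-fold higher number from compound 1 to compound 3 (0.17 log units; that floor lies within the scatter), whose floor also lies within the scatter, so neither change is shown to move the read-out beyond the scatter, although both steps are open upward and neither shows a lower number.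

The compounds shown leave open how far the true value of compound 3 lies past its limit, and so whether either step in fact goes beyond the scatter. They also leave open how a bromo group, an amine or a carboxylic acid on that same aromatic carbon would read in this assay.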